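The source may hold more compounds than are shown below. What is called first, only, known or untested is meant among the compounds shown, and "the series" means these compounds.

Compound 1 `O=C(Oc1ccc(OCc2ccccc2)cc1)N(Cc1ccccc1)S(=O)(=O)c1ccc(Cl)cc1`: 44.9%
Compound 2 `O=C(Nc1ccc(OCCCCc2ccccc2)cc1)N(Cc1ccccc1)S(=O)(=O)c1ccc(Cl)cc1`: > 100% (a limit)

Among the measured compounds shown here, in an ADME assay on microsomes from liver (Homo sapiens) for metabolic stability, read by LC-MS, using NADPH, with a stated time of 30 min, tested at 1 uM (on this read-out higher numbers stand for a more stable compound and lower numbers for a less stable compound), compound 1 gives 44.9%, the only exact number available. The reading for compound 2, > 100%, is a limit of the assay. Compound 3 `O=C(Oc1ccc(OCc2ccccc2)cc1)N(Nc1ccccc1)S(=O)(=O)c1ccc(Cl)cc1` keeps the core of compound 1 but carries anilino in place of benzyl on an amide-type nitrogen. For the measured compounds named here, no measured pair shows this change, so no large shift in either direction is expected. The estimated step of a number 4.9 percentage points lower from compound 1 to compound 3 (within the scatter) stays within the usual scatter. For compound 3, the expected value is 40%, within an estimated range of 15% to 70%.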

Compound 3, percent of the compound remaining: 66.6%
Beside the measured number, compound 3's estimate is 26.6 percentage points below it; low and high end bracket the measured number.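

In this assay, among the compounds shown here, anilino in place of benzyl on an amide-type nitrogen gives a number 21.7 percentage points higher from compound 1 to compound 3 (beyond the scatter) and is the first single-place comparison here. It shows that this position, whose other neighbours are the carbonyl carbon and the sulfonyl sulfur, responds to a change of group. Anilino brings a hydrogen-bond donor and acceptor that benzyl lacks, but the data shown give no cause for this step.

As far as these compounds go, whether a methyl group, a longer chain or a cyclohexylamino group on this nitrogen would move the read-out the same way stays open. From the compounds shown here alone, whether the step carries over to a urea such as compound 2 also stays open.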